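Halogen Swaps in Three Measured Compounds and a Fourth

The source may report more compounds than this note shows. Statements on the series, on what has been measured and on what is new or still open speak of the compounds shown alone.

Three compounds have been tested in a functional assay on PC-3 cells (Homo sapiens) for cytotoxicity, read by MTT assay, with a stated time of 72 h; a higher number here means a weaker inhibitor, a lower number a stronger inhibitor:
compound 1 `COc1ccc(S(=O)(=O)c2nc3ccccc3nc2Nc2ccc(F)cc2)cc1` gives 2200 nM;
compound 2 `COc1ccc(S(=O)(=O)c2nc3ccccc3nc2Nc2ccc(Cl)cc2)cc1` gives 31800 nM;
compound 3 `O=S(=O)(c1ccc(Br)cc1)c1nc2ccccc2nc1Nc1ccc(F)cc1` gives 9160 nM.

Compound 2 differs from compound 1 by chloro in place of fluoro on an aromatic carbon, and that change brought a 14-fold higher number from compound 1 to compound 2 (1.16 log units; beyond the scatter). The core of compound 3 differs from that of compound 1 by bromo in place of methoxy on an aromatic carbon, which brought a 4.2-fold higher number from compound 1 to compound 3 (0.62 log units; beyond the scatter). Compound 4 `O=S(=O)(c1ccc(Br)cc1)c1nc2ccccc2nc1Nc1ccc(Cl)cc1` has not yet been measured. It differs from compound 3 by chloro in place of fluoro on an aromatic carbon, the same change that turned compound 1 into compound 2, at the same place; among these four compounds it occurs twice in all.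

Going by the values given here, only one earlier instance of this change exists, and it sits on a different core, so the size of the second step is uncertain. Still, because the earlier instance gave a 14-fold higher number from compound 1 to compound 2 (1.16 log units; beyond the scatter), compound 4 is expected to give a higher number than compound 3, and the estimated step is a 5.5-fold higher number from compound 3 to compound 4 (0.74 log units; beyond the scatter). Compound 4 is therefore expected to come out near 50000 nM, most likely between 12000 nM and 200000 nM, with some chance that this assay reports only a limit.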

Compound 4, half-maximal inhibitory concentration: 7460 nM
Beside the measured number, compound 4's estimate is 6.7-fold (0.83 log units) above it; the measured number lies below the stated range.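

In this assay, chloro in place of fluoro on the core of compound 3 brought a 1.2-fold lower number from compound 3 to compound 4 (0.09 log units; within the scatter), so the large step seen on the core of compound 1 did not carry over, and the two instances differ: the same change on two cores in this assay, a 14-fold higher number (1.16 log units; beyond the scatter) from compound 1 to compound 2 and a 1.2-fold lower number (0.09 log units; within the scatter) from compound 3 to compound 4, 18-fold (1.25 log units) apart, beyond the scatter of two such steps

Read the other way, bromo in place of methoxy brought a 4.3-fold lower number from compound 2 to compound 4 (0.63 log units; beyond the scatter), opposite in direction to its earlier instance, so the size and direction of this change also depend on the group at the other place: the same change on two cores in this assay, a 4.2-fold higher number (0.62 log units; beyond the scatter) from compound 1 to compound 3 and a 4.3-fold lower number (0.63 log units; beyond the scatter) from compound 2 to compound 4, 18-fold (1.25 log units) apart, beyond the scatter of two such steps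

These four compounds thus show that the two changes do not add up independently in this series, but they do not show why, and two instances of each change give no rule for predicting the step on a further core.

The compounds shown leave open how the step from fluoro to chloro would run with a methyl group or an amine in place of the methoxy or bromo. They also leave open what a nitrile or bromo would give in place of the fluoro.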